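Compound 1 and its bis(2-hydroxyethyl)amino relative

A few compounds are considered here, and "the series" means these few. Any claim that something is new, unique, unknown or untested is made for them only; others in the source may bear on it.

Compound 1 `COc1cc(NC(C)CCCNC(=O)NCCCO)c2ncccc2c1` has no true number yet in a functional assay on NCI-H460 cells (Homo sapiens) (on this read-out lower numbers stand for stronger inhibition and higher numbers for weaker inhibition), so far. Compound 1 reads > 100000 nM here, which is a limit of the assay and not a number. Compound 3 `COc1cc(NC(C)CCCNC(=O)NC(CO)(CO)CO)c2ncccc2c1` reads > 100000 nM here, which is also a limit. All comparisons must be read against the limit of > 100000 nM in this assay, at which 2 of the 3 values shown sit, for now. Only compound 2 `COc1cc(NC(C)CCCNC(=O)NCCCCCO)c2ncccc2c1` gives a number, 2000 nM in this set.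

The 5-hydroxypentyl chain of compound 2 marks a large step, an at least 50-fold lower number from compound 1 to compound 2 (1.69 log units; beyond the scatter) on the measured scale. The 2-hydroxy-1,1-bis(hydroxymethyl)ethyl group of compound 3 marks another, an at least 50-fold higher number from compound 2 to compound 3 (1.69 log units; beyond the scatter) on the same scale.

Compound 4 `COc1cc(NC(C)CCCNC(=O)N(CCO)CCO)c2ncccc2c1` changes the same part of compound 1: bis(2-hydroxyethyl)amino in place of (3-hydroxypropyl)amino on a carbonyl carbon with bis(2-hydroxyethyl)amino in place of (3-hydroxypropyl)amino on a carbonyl carbon. Compound 4 lacks the 5-hydroxypentyl chain behind an at least 50-fold lower number from compound 1 to compound 2 (1.69 log units; beyond the scatter) so no large gain is expected in this assay here. The expected outcome is an at least 1.1-fold lower number from compound 1 to compound 4 (0.04 log units; that floor lies within the scatter) at most a modest shift. Compound 4 is estimated at 90000 nM with an expected range of 20000 nM to 200000 nM and may well return only a limit.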

Compound 4, half-maximal inhibitory concentration: > 100000 nM
Compound 4 gave a limit, no number (the forecaster's own chance of this, stated with the estimate: 65%); middle value at least 1.1-fold (0.04 log units) from the limit.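

Putting bis(2-hydroxyethyl)amino in place of (5-hydroxypentyl)amino on the carbonyl carbon gives an at least 50-fold higher number from compound 2 to compound 4 (1.69 log units; beyond the scatter) in this assay. Among the compounds shown here, a second hydroxy-bearing arm on this nitrogen therefore does not recover what the single 5-hydroxypentyl chain gives, and compound 2 remains the only compound here with a true number. The steps from compound 1 and from compound 3 to compound 4 cannot be read because both ends of each step are limits: the limit of > 100000 nM in this assay, at which 3 of the 4 values shown sit.

The compounds shown leave open whether a longer chain ending in hydroxy would give a lower number than compound 2. They also leave open whether the hydroxy itself matters, which a plain pentyl chain, or a chain ending in an amine or a carboxylic acid, could test.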